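A few compounds are considered here, and "the series" means these few. Any claim that something is new, unique, unknown or untested is made for them only; others in the source may bear on it.

Compound 1 `Cc1ccc(C)c(N2CCN(C(=O)c3oc(C)nc3-c3ccccc3)CC2)c1` has been tested in a functional assay on HL-60 cells (Homo sapiens) for inhibition, read by MTT assay, with a stated time of 72 h (on this read-out higher numbers stand for weaker inhibition and lower numbers for stronger inhibition), where compound 1 gives 31.3 nM. Of the two compounds that have a reported number, compound 1 has the lower one. Its nearest neighbour is compound 2 `Cc1ccc(C)c(N2CCN(C(=O)c3oc(C)nc3-c3cccc(Cl)c3)CC2)c1`, which in this assay gives 345 nM, a change of an 11-fold higher number from compound 1 to compound 2 (1.04 log units; beyond the scatter) brought about by chloro in place of hydrogen on an aromatic carbon. Compound 3 `Cc1ccc(C)c(N2CCN(C(=O)c3oc(C)nc3-c3ccc(Cl)cc3)CC2)c1` was reported in this assay as "not active" (no number reported), with no number given.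

Compound 4 `Cc1nc(-c2ccccc2)c(C(=O)N2CCN(c3c(C)cccc3C)CC2)o1` has not yet been measured. It differs from compound 1 by 2,6-dimethylphenyl in place of 2,5-dimethylphenyl on an amine nitrogen in a ring; the two groups consist of the same atoms, joined differently. Among the measured compounds shown here, no measured step touches this part of the molecule: the only known step alters an aromatic carbon elsewhere in the shared core, so nothing among the measured compounds speaks for a shift beyond the usual scatter. The step expected is therefore a 1.6-fold higher number from compound 1 to compound 4 (0.20 log units; within the scatter). Compound 4 is estimated at 50 nM, with a range from 12 nM to 250 nM.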

Compound 4, half-maximal inhibitory concentration: 146 nM
Compound 4: middle estimate off by 2.9-fold (0.47 log units), on the low side; low and high end bracket the measured number.
By their numbers in this assay, from the lowest: compound 1; then compound 4; then compound 2.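

In this assay the dimethylphenyl group on the ring nitrogen proves sensitive to small changes: replacing 2,5-dimethylphenyl with 2,6-dimethylphenyl gives a 4.7-fold higher number from compound 1 to compound 4 (0.67 log units; beyond the scatter) and lies beyond the usual scatter. The earlier step concerned only an added chloro elsewhere in the shared core, whereas this one shows that the number can shift when the two groups have the same atoms, joined differently. Nothing measured here gives a reason for this shift.

Going by these compounds, it remains open how a plain phenyl, a methoxyphenyl or a pyridyl group would fare on this ring nitrogen. It is also unknown whether the 2,6-dimethylphenyl change would have a similar effect in a compound that also carries a chloro on the shared core.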